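Removing the Silicon-Bearing Group from Compound 2

The source may hold more compounds than are shown below. What is called first, only, known or untested is meant among the compounds shown, and "the series" means these compounds.

Among the compounds with values here, compound 2 `C[C@H]1CC(Cl)=C([Si](C)(C)C)[C@@H](C2CCCCC2)O1` is the only member of this small set with an actual number: in a functional assay on WiDr cells (Homo sapiens) for antiproliferative activity (on this read-out higher numbers stand for weaker inhibition of growth and lower numbers for stronger inhibition of growth), compound 2 gives 15000 nM. Its neighbour compound 1 `CCC(C)[C@H]1O[C@@H](C)CC(Cl)=C1[Si](C)(C)C` differs only in carrying sec-butyl where compound 2 carries cyclohexyl on a saturated ring carbon. In this assay compound 1 reaches only a limit, > 100000 nM, not a measured number. the limit of > 100000 nM in this assay, at which 1 of the 2 values shown sits, marks that boundary. Within the data shown here, the one step that can be quantified, an at least 6.6-fold lower number from compound 1 to compound 2 (0.82 log units; beyond the scatter), therefore says only that the cyclohexyl compound reaches a measurable number.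

Compound 3 `C[C@H]1CC(Cl)=C[C@@H](C2CCCCC2)O1` has not been tested. It differs from compound 2 in one place: a hydrogen atom in place of a group of 4 heavy atoms (3 carbon, 1 silicon; no ring), on a double-bonded ring carbon. Among the measured compounds shown here, no measured step touches this group; the only step on record concerns the substituent on the saturated ring carbon, not the double-bonded one. Nothing in the numbers points in either direction, so no step beyond the scatter can be predicted, and the range must stay wide. The expected step of no change at the digits printed from compound 2 to compound 3 (within the scatter) is essentially flat. Compound 3 is estimated at 15000 nM, within 4000 nM to 80000 nM.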

Compound 3, concentration for 50% growth inhibition: 65000 nM
Compound 3: middle estimate off by 4.3-fold (0.64 log units), on the low side; the range from low to high includes it.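

Replacing the silicon-bearing group with a hydrogen atom gives, in this assay, a 4.3-fold higher number from compound 2 to compound 3 (0.64 log units; beyond the scatter), so what sits on this double-bonded ring carbon affects the read-out, and the compound that keeps the silicon-bearing group shows the stronger inhibition of growth. The earlier step concerned only the saturated ring carbon and could say nothing about this place, whereas compound 3 also shows that a measured number is still reached without the silicon-bearing group. Nothing measured here tells which feature of the leaving group accounts for this step.

Only one replacement at this carbon is shown, so it remains open whether a tert-butyl group, a methyl group or a phenyl ring there would stay close to compound 2, stay close to compound 3 or fall elsewhere. The chloro and methyl groups are the same in all the compounds shown, so it also remains open what an amine or a carboxylic acid in either of those places would do to the inhibition of growth.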